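The compounds below may be only part of what the source reports. "The series", "measured", "known", "first", "only" and "open" are said of these compounds alone.

Compound 2 `CCCSc1nc(N/N=C(\C)c2ccccc2O)c2nnn(Cc3ccccc3)c2n1` gives 11100 nM in a functional assay on ECa-109 cells (Homo sapiens) for antiproliferative activity, read by MTT assay, with a stated time of 72 h (a lower number here means a stronger inhibitor, a higher number a weaker inhibitor), and stands alongside compound 1 `CCCSc1nc(N/N=C(\C)c2ccccc2O)c2nnn(Cc3ccc(Cl)cc3)c2n1`, which gives 11200 nM in this assay; the two lie within the scatter of each other, as the step shows: a 1.0-fold lower number from compound 1 to compound 2 (0.00 log units; within the scatter). Compound 3 `CCCSc1nc(N/N=C(\C)c2ccccc2O)c2nnn(Cc3ccc(Br)cc3)c2n1` differs from compound 2 by bromo in place of hydrogen on an aromatic carbon. Going by the values given here, the only measured step that bears on this change, the one already given, swapped chloro for hydrogen at the same place on the benzyl group and left this assay unchanged, so no step beyond the scatter is expected here. The expected step is a 1.0-fold lower number from compound 2 to compound 3 (0.00 log units; within the scatter). Compound 3 is therefore estimated at 11000 nM, with a range from 5000 nM to 25000 nM.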

Compound 3, half-maximal inhibitory concentration: 36100 nM
For compound 3 the middle estimate is 3.3-fold (0.52 log units) below the measured one; the whole stated range lies below it.
By their numbers in this assay, from the lowest: compounds 2 and 1 (each within the scatter of the next); then compound 3.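

In this assay, going by these compounds alone, the change from benzyl to 4-bromobenzyl is the first at this place to move the number beyond the scatter, with a 3.3-fold higher number from compound 2 to compound 3 (0.51 log units; beyond the scatter). Bromo also parts from chloro at the same aromatic carbon, with a 3.2-fold higher number from compound 1 to compound 3 (0.51 log units; beyond the scatter), so the halogens do not read alike here, although chloro and hydrogen lie within the scatter of each other. No data here bear on the origin of this gap. Still open, on these data alone, is how fluoro, iodo, methoxy or an amine would read at this carbon, and whether the bromo step holds with a longer chain on the sulfur.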